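The source may hold more compounds than are shown below. What is called first, only, known or untested is meant among the compounds shown, and "the series" means these compounds.

Among the compounds with values here, compound 1 `CCN(CC)CCn1c(N)c(-c2nc3ccccc3[nH]2)c2nc(C#N)c(C#N)nc21` is the one compound here with a measured number: in a functional assay on cells (Homo sapiens) for antiproliferative activity, read by MTT assay, with a stated time of 48 h (on this read-out lower numbers stand for stronger inhibition and higher numbers for weaker inhibition), compound 1 gives 25400 nM. Its partner compound 2 `N#Cc1nc2c(-c3nc4ccccc4[nH]3)c(N)n(CCN3CCCC3)c2nc1C#N` is known only through a limit of the assay, since in this assay compound 2 gives > 50000 nM. The step from the first to the second is therefore only a floor, an at least 1.9-fold higher number from compound 1 to compound 2 (0.29 log units; that floor lies within the scatter), and its size rests on (the limit of > 50000 nM in this assay, at which 1 of the 2 values shown sits).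

Compound 3 `CN1CCN(CCCn2c(N)c(-c3nc4ccccc4[nH]3)c3nc(C#N)c(C#N)nc32)CC1` changes compound 1 at the same place: (4-methylpiperazin-1-yl)methyl in place of diethylamino on a saturated chain carbon, two bonds along the chain from an aromatic nitrogen. Within the data shown here, the one measured step that bears on this change is the exchange of the diethylamino for pyrrolidin-1-yl, which gave an at least 1.9-fold higher number from compound 1 to compound 2 (0.29 log units; that floor lies within the scatter); that floor lies within the scatter, so it gives no firm direction, but the measured companion of compound 1 did not come out stronger. Compound 3 is therefore expected to sit close to compound 1, with the step of a 1.6-fold higher number from compound 1 to compound 3 (0.20 log units; within the scatter) as the most likely outcome, and a fair chance that only a limit is returned. The estimate for compound 3 in this assay is 40000 nM, with a range from 12000 nM to 150000 nM.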

Compound 3, half-maximal inhibitory concentration: 4520 nM
Beside the measured number, compound 3's estimate is 8.8-fold (0.95 log units) above it; the measured number lies below the stated range.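

The chain on the aromatic nitrogen proves to be a place where the number in this assay can move beyond the scatter, which the earlier pair, with its floor within the scatter, could not show. Replacing diethylamino with (4-methylpiperazin-1-yl)methyl gives a 5.6-fold lower number from compound 1 to compound 3 (0.75 log units; beyond the scatter), and replacing pyrrolidin-1-yl with the same group gives an at least 11-fold lower number from compound 2 to compound 3 (1.04 log units; beyond the scatter). Compound 2 is known only through a limit of the assay, so the second step is a floor rather than a measured size: the limit of > 50000 nM in this assay, at which 1 of the 3 values shown sits.

The change to compound 3 brings in the six-membered ring with its second nitrogen and lengthens the chain in one move, as 2-(diethylamino)ethyl becomes 3-(4-methylpiperazin-1-yl)propyl, so the compounds shown cannot assign the lower number to either the ring or the chain length. A 3-(diethylamino)propyl chain would test the chain length with the amine of compound 1 kept in place, and a 2-(4-methylpiperazin-1-yl)ethyl chain would test the ring at the length of compound 1.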